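A few compounds are considered here, and "the series" means these few. Any claim that something is new, unique, unknown or untested is made for them only; others in the source may bear on it.

Measured compounds:
compound 1 `O=C1COc2ccc(-c3cnc(Cl)c(NS(=O)(=O)c4ccc(F)cc4)c3)cc2N1c1ccccc1` — 36900 nM
compound 2 `O=C1COc2ccc(-c3cnc4ccccc4c3)cc2N1c1ccccc1` — > 40000 nM

The study tested antiproliferative activity in a functional assay on A-375 cells (Homo sapiens) for antiproliferative activity, read by MTT assay, with a stated time of 72 h; on this read-out higher numbers stand for weaker inhibition and lower numbers for stronger inhibition. Among the measured compounds shown here, compound 1 gives 36900 nM in this assay, and this is the only number recorded. Compound 2 returns a limit rather than a number, > 40000 nM. One of the two values sits at the limit of > 40000 nM in this assay, at which 1 of the 2 values shown sits, so compound 1 cannot be placed above or below compound 2 on these results; only its own weak inhibition is known.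

Compound 3 `O=C1COc2ccc(-c3cnc(Cl)c(NS(=O)(=O)c4ccc(F)cc4)c3)cc2N1c1ccc(Cl)cc1` has not yet been measured in this assay. It differs from compound 1 by chloro in place of hydrogen on an aromatic carbon. For the measured compounds named here, no pair of measured compounds shares this change, so nothing here shows how such a substitution moves the read-out. A single chloro entering on the aromatic ring is a small alteration, and the step from compound 1 to compound 3 is expected to stay within the usual scatter, with no clear direction: a 1.3-fold lower number from compound 1 to compound 3 (0.12 log units; within the scatter). On this basis compound 3 is estimated at 28000 nM, between 10000 nM and 70000 nM, in this assay.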

Compound 3, half-maximal inhibitory concentration: 30600 nM
Compound 3: middle estimate off by 1.1-fold (0.04 log units), on the low side; the range from low to high includes it.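

In this assay, putting chloro in place of hydrogen on an aromatic carbon, para to a large group, gives a 1.2-fold lower number from compound 1 to compound 3 (0.08 log units; within the scatter), the only step shown between measured compounds that differ in one place. At this position, therefore, the swap from phenyl to 4-chlorophenyl does not separate the two compounds, as the step lies within the usual scatter and both compounds remain weak inhibitors on this read-out. Compound 2 has a limit rather than a number, so it gives no second step to set beside this one: the limit of > 40000 nM in this assay, at which 1 of the 3 values shown sits.

With a single substituent tested at this position, the data leave open whether a methoxy group, an amine or a carboxylic acid in the place of the chloro would move the read-out beyond the scatter. They also leave open whether any single change elsewhere on the core of compound 1, such as a methyl group or an amine in place of its other chloro, would give a step that can be told apart from the scatter.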